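A Side Chain Swap on Compound 1

The compounds below may be only part of what the source reports. "The series", "measured", "known", "first", "only" and "open" are said of these compounds alone.

Values so far in a toxicity assay on GES1 cells (Homo sapiens) for inhibition, read by MTT assay, with a stated time of 72 h (on this read-out higher numbers stand for weaker inhibition and lower numbers for stronger inhibition), are:
- compound 1 `Cc1cc(N2CC[C@@H](C)[C@@H](N(C)c3ncnc4[nH]ccc34)C2)n2nc(SCc3nc4ccccc4[nH]3)nc2n1` gives 40200 nM as its reading
- compound 2 `C[C@@H]1CCN(c2cc(-c3ccccc3)nc3ncnn23)C[C@@H]1N(C)c1ncnc2[nH]ccc12` gives > 100000 nM as its reading, which is a limit of the assay and not a number
- compound 3 `Cc1nc2nc(SCc3ccc(Cl)cc3)nn2c(N2CC[C@@H](C)[C@@H](N(C)c3ncnc4[nH]ccc34)C2)c1C` gives 99200 nM as its reading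

Among the compounds with values here, only two of these readings are true numbers, and compound 1 holds the lower one. Compound 3 is its nearest neighbour, and the gap between them lies beyond the usual scatter.

Compound 4 `C=CCSc1nc2nc(C)cc(N3CC[C@@H](C)[C@@H](N(C)c4ncnc5[nH]ccc45)C3)n2n1` has not yet been measured. It keeps the core of compound 1 and changes one side chain: vinyl in place of 1H-benzimidazol-2-yl on a saturated chain carbon bound to a sulfur (in words, vinyl in place of 1H-benzimidazol-2-yl on a saturated chain carbon bound to a sulfur). Put more broadly, (1H-benzimidazol-2-yl)methyl becomes allyl.

Within the data shown here, no two measured compounds differ in just one place, so no measured step guides this change directly. The best clue is compound 3, which also lacks the 1H-benzimidazol-2-yl group and gives 99200 nM in this assay as its reading. A moderate rise in the number, meaning weaker inhibition, is therefore expected. The estimated change is a 2.2-fold higher number from compound 1 to compound 4 (0.35 log units; beyond the scatter) in that direction. Compound 4 is expected at about 90000 nM in this assay, with an estimated range from 35000 nM to 200000 nM overall.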

Compound 4, half-maximal inhibitory concentration: > 100000 nM
Compound 4 was reported as a limit (the forecaster's own chance of this, stated with the estimate: 40%); middle value at least 1.1-fold (0.04 log units) from the limit.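

Within the data shown here, this is the first step measured at this position, on a saturated chain carbon bound to a sulfur. In this assay, exchanging 1H-benzimidazol-2-yl for vinyl, which turns the (1H-benzimidazol-2-yl)methyl side chain into allyl, gives an at least 2.4-fold higher number from compound 1 to compound 4 (0.39 log units; beyond the scatter), so the smaller side chain goes with weaker inhibition in this pair. Compound 4 reads > 100000 nM, which is a limit of the assay and not a number, so the direction of the step is clear while its full size stays unknown, since the reading stops at the edge of what the assay reports: the limit of > 100000 nM in this assay, at which 2 of the 4 values shown sit.

The compounds shown leave open which part of the 1H-benzimidazol-2-yl group matters, since this single swap removes both of its aromatic rings and its hydrogen-bond donor and acceptor at once. On these data alone, it also remains open how this toxicity reading would respond to other groups on the same saturated chain carbon, such as a plain phenyl ring, an amine or a carboxylic acid, any of which could show whether a numerical reading returns.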